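Aminothiazole guanidine series: replacing the arylalkyl group

The source may report more compounds than this note shows. Statements on the series, on what has been measured and on what is new or still open speak of the compounds shown alone.

Working notes on two measured compounds and one awaiting data. Compound 1 `Cc1nc(N)sc1CCCN/C(N)=N/C(=O)N[C@H](C)c1ccccc1` is the stronger of the pair: in an assay on membranes from Sf9 cells for displacement of a labelled ligand from histamine H2 receptor (Homo sapiens), read by scintillation counting, with a stated time of 60 min (on this read-out lower numbers stand for stronger inhibition and higher numbers for weaker inhibition), compound 1 gives 17.8 nM, the lowest of the two numbers available. Compound 2 `Cc1nc(N)sc1CCCN/C(N)=N/C(=S)N[C@H](C)c1ccccc1` sits on the other end; in this assay compound 2 gives 115 nM, a gap from compound 1 that lies beyond the usual scatter. Among the measured compounds shown here, no single-point step between measured compounds is recorded, so the series offers no direct precedent for swapping the group on the amide-type nitrogen.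

Compound 3 `Cc1nc(N)sc1CCCN/C(N)=N/C(=O)NC1CCCCC1` carries exactly that swap relative to compound 1: cyclohexyl in place of 1-phenylethyl on an amide-type nitrogen. The change removes the aromatic ring and the defined stereocentre and leaves a saturated ring of the same size; donors and acceptors are unchanged. For the measured compounds named here, with no measured analogue of this kind, a step toward weaker binding is expected, of modest size, though a result within the scatter of compound 1 remains plausible. The expected step is a 2.2-fold higher number from compound 1 to compound 3 (0.35 log units; beyond the scatter), and compound 3 is estimated at 40 nM, with a likely range from 12 nM to 130 nM.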

Compound 3, inhibition constant: 170 nM
The estimate for compound 3 lay 4.3-fold (0.63 log units) below the measured number; measured number above the stated range.
By their numbers in this assay, from the lowest: compound 1; then compounds 2 and 3 (each within the scatter of the next).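

In this assay, the series now has its first single-place step at this amide-type nitrogen: cyclohexyl in place of 1-phenylethyl gives a 9.6-fold higher number from compound 1 to compound 3 (0.98 log units; beyond the scatter), which lies beyond the scatter. The position is therefore not indifferent to this exchange, and a saturated six-membered ring does not stand in for the 1-phenylethyl group of compound 1 on this read-out. The aromatic ring and the defined stereocentre both leave in this one step, so the step cannot be assigned to either of them alone, and nothing at hand bears on its cause.

The compounds shown leave open which of these two features accounts for the step: a benzyl group on the same nitrogen would keep the aromatic ring without the stereocentre, while a 1-cyclohexylethyl group would keep the stereocentre without the aromatic ring. On these data alone, it also remains open whether a step of similar size would appear on the thiocarbonyl counterpart, compound 2, when the same cyclohexyl group replaces its 1-phenylethyl group.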